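A few compounds are considered here, and "the series" means these few. Any claim that something is new, unique, unknown or untested is made for them only; others in the source may bear on it.

Among the measured compounds, compound 1 `CCCCCCCCCCCCCCNC(=O)[C@@H](N)[C@@H](C)O` gives 18700 nM in a functional assay on SW-620 cells (Homo sapiens) for cytotoxicity, read by MTT assay, with a stated time of 48 h (on this read-out lower numbers stand for stronger inhibition and higher numbers for weaker inhibition), the smallest number of the three, although compound 2 `CCCCCCCCCCCCCCCCCCNC(=O)[C@@H](N)[C@@H](C)O` with 21400 nM and compound 3 `CCCCCCCCCCCCNC(=O)[C@@H](NC(=O)c1cc2ccccc2o1)[C@@H](C)O` with 21300 nM both lie within the usual scatter of it. Compound 4 `CCCCCCCCCCCCCCNC(=O)[C@@H](NC(=O)c1ccccc1)[C@@H](C)O` differs from compound 1 by benzoyl in place of hydrogen on an amine nitrogen. For the measured compounds named here, the only measured single step, a 1.1-fold higher number from compound 1 to compound 2 (0.06 log units; within the scatter), alters the chain rather than this nitrogen, so it does not speak to the change directly. Compound 3, which also carries an acyl group on this nitrogen, shows a value close to compound 1 in this assay. Compound 4 is therefore expected to move by a 1.1-fold higher number from compound 1 to compound 4 (0.03 log units; within the scatter), no step beyond the scatter. The estimated value of compound 4 is 20000 nM, within 8000 nM to 50000 nM.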

Compound 4, half-maximal inhibitory concentration: 200000 nM
Estimate against measurement, compound 4: 10-fold (1.00 log units) below; the whole stated range lies below it.
By their numbers in this assay, from the lowest: compounds 1, 3 and 2 (each within the scatter of the next); then compound 4.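

In this assay, the amine nitrogen proves sensitive to substitution: benzoyl in place of hydrogen gives an 11-fold higher number from compound 1 to compound 4 (1.03 log units; beyond the scatter). For the compounds shown here, the only earlier single step, a 1.1-fold higher number from compound 1 to compound 2 (0.06 log units; within the scatter), altered the chain and stayed within the scatter, so this is the first sign that a single change can shift the number clearly on this core. Nothing available here accounts for the size of this step. From the compounds shown here alone, whether acetyl or benzyl on this nitrogen of compound 1 would shift the number as far remains open.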